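The source may report more compounds than this note shows. Statements on the series, on what has been measured and on what is new or still open speak of the compounds shown alone.

Among the compounds with values here, compound 1 `O=C(/C=C/c1cn(-c2ccccc2)nc1-c1ccsc1)c1ccccc1` stands highest of the three numbers measured so far: in a functional assay on HCT-116 cells (Homo sapiens) for inhibition, read by sulforhodamine B assay, with a stated time of 72 h (a higher number here means a weaker inhibitor, a lower number a stronger inhibitor), compound 1 gives 5100 nM. Its two neighbours change only the aryl group on the carbonyl carbon. Compound 2 `COc1ccc(C(=O)/C=C/c2cn(-c3ccccc3)nc2-c2ccsc2)cc1OC` gives 1600 nM in this assay, and compound 3 `COc1ccc(C(=O)/C=C/c2cn(-c3ccccc3)nc2-c2ccsc2)c(OC)c1` gives 2200 nM; the step of a 3.2-fold lower number from compound 1 to compound 2 (0.50 log units; beyond the scatter) and the step of a 2.3-fold lower number from compound 1 to compound 3 (0.37 log units; beyond the scatter) are both beyond the scatter, while the step of a 1.4-fold higher number from compound 2 to compound 3 (0.14 log units; within the scatter) is not.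

Compound 4 `O=C(/C=C/c1cn(-c2ccccc2)nc1-c1ccncc1)c1ccccc1` differs from compound 1 elsewhere: pyridin-4-yl in place of thiophen-3-yl on an aromatic carbon. Within the data shown here, none of the measured steps touches this position, so none of them bears directly on the change; they only show that the shared core tolerates modest moves at the carbonyl end. With no guide at the changed position, the expectation is a step in this assay of no more than the scatter, in either direction. Compound 4 is therefore estimated at 4500 nM, with a range from 1500 nM to 14000 nM, which corresponds to the expected step of a 1.1-fold lower number from compound 1 to compound 4 (0.05 log units; within the scatter).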

Compound 4, half-maximal inhibitory concentration: 3100 nM
For compound 4 the middle estimate is 1.5-fold (0.16 log units) above the measured one, within the range that was stated.
By their numbers in this assay, from the lowest: compounds 2, 3, 4 and 1 (each within the scatter of the next, the first and the last beyond it).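

Within the data shown here, this is the first view of the aromatic group on the five-membered ring of the shared core, since the earlier steps all changed the group on the carbonyl carbon. In this assay, the step for pyridin-4-yl in place of thiophen-3-yl is a 1.6-fold lower number from compound 1 to compound 4 (0.22 log units; within the scatter), so the two compounds cannot be told apart, even though a six-membered ring with a nitrogen has replaced a five-membered ring with a sulfur. Nothing available explains why the two rings read alike here.

The compounds shown leave open how this position would respond to a group of another kind, such as a simple amine, a carboxylic acid or a longer alkyl chain. They also leave open whether pyridin-4-yl and the 3,4-dimethoxyphenyl group would act independently in one molecule.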